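From an oxygen link to a nitrogen link: compound 4

The compounds below may be only part of what the source reports. "The series", "measured", "known", "first", "only" and "open" are said of these compounds alone.

Measured so far in a functional assay on HEK293 cells for antagonist activity at thromboxane A2 receptor (Homo sapiens), read by fluorescence and calcium flux; on this read-out lower numbers stand for stronger inhibition and higher numbers for weaker inhibition:
compound 1, `Cc1ccccc1Oc1ccc(C#N)cc1S(=O)(=O)NC(=O)NC(C)C`, 8680 nM
compound 2, `CC(C)NC(=O)NS(=O)(=O)c1cc(C#N)ccc1Oc1ccc(F)cc1`, 9620 nM
compound 3, `CC(C)NC(=O)NS(=O)(=O)c1cc(C#N)ccc1Oc1ccc(Br)cc1`, 9470 nM

All three compounds share one core and differ only in the ring that hangs on the oxygen. Compound 3 sits close to both of its neighbours: the change from compound 2 to compound 3 gives a 1.0-fold lower number from compound 2 to compound 3 (0.01 log units; within the scatter), and the change from compound 1 to compound 3 gives a 1.1-fold higher number from compound 1 to compound 3 (0.04 log units; within the scatter). Neither step reaches beyond the scatter, so the three numbers are best read as one level.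

Compound 4, `Cc1ccccc1Nc1ccc(C#N)cc1S(=O)(=O)NC(=O)NC(C)C`, is not yet measured. Relative to compound 3 it carries a different side group: (2-methylphenyl)amino in place of 4-bromophenoxy on an aromatic carbon. This change has two parts. The ring part, a 2-methylphenyl in place of a halogen-bearing phenyl, was already tested in the step from compound 1 to compound 3, which gave a 1.1-fold higher number from compound 1 to compound 3 (0.04 log units; within the scatter), within the scatter. Going by the values given here, the second part, an amine in place of the ether oxygen, has no measured counterpart here, so the data give no direction for it.

Compound 4 is therefore expected to land near the shared level, with a 1.1-fold lower number from compound 3 to compound 4 (0.02 log units; within the scatter) as the estimated step. From the compounds shown here alone, the estimate for compound 4 is 9000 nM, with a range from 3000 nM to 27000 nM, kept wide because the amine link is untested.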

Compound 4, half-maximal inhibitory concentration: 7240 nM
Compound 4: the middle estimate sits 1.2-fold (0.09 log units) above what was measured; measured number inside the range.
By their numbers in this assay, from the lowest: compounds 4, 1, 3 and 2 (each within the scatter of the next).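

Compound 1 and compound 4 carry the same 2-methylphenyl ring, so this pair isolates the link itself: in this assay, (2-methylphenyl)amino in place of 2-methylphenoxy gives a 1.2-fold lower number from compound 1 to compound 4 (0.08 log units; within the scatter). Thus, on this aromatic carbon, an amine link and an oxygen link cannot be told apart, and the two steps that change the ring and the link together, a 1.3-fold lower number from compound 3 to compound 4 (0.12 log units; within the scatter) and a 1.3-fold lower number from compound 2 to compound 4 (0.12 log units; within the scatter), also stay within the scatter, even though (2-methylphenyl)amino counts 1 hydrogen-bond donor where 4-bromophenoxy and 4-fluorophenoxy, as oxygen-linked groups, do not carry that amine hydrogen. No independent measurement is available that could explain why the four compounds stay on one level.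

The compounds shown leave open whether a sulfur or methylene link, or a methyl group on the amine nitrogen, would move the number beyond the scatter. They also leave open whether a carboxylic acid or a longer chain on the ring hanging from the link would do so, and whether any such change would matter with an amine link as much as with an oxygen link.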